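The source may hold more compounds than are shown below. What is called first, only, known or untested is meant among the compounds shown, and "the series" means these compounds.

Measured compounds: compound 1 `FC(F)(F)c1cccc(-c2nc3cnc(Nc4cccnn4)cc3[nH]2)c1` gives 51% in an ADME assay on microsomes from liver (Mus musculus) for metabolic stability, read by LC-MS, with a stated time of 30 min, tested at 0.1 uM; on this read-out lower numbers stand for a less stable compound and higher numbers for a more stable compound; compound 2 `Fc1ccc(-c2nc3cnc(Nc4ccccn4)cc3[nH]2)cc1F` gives 7.5%; compound 3 `Fc1ccc(-c2nc3cnc(Nc4ccc(C(F)(F)F)cn4)cc3[nH]2)cc1F` gives 89%.

Compound 3 stands highest of the three, with compound 1 nearest and compound 2 furthest, both differences beyond the scatter. Compound 4 `FC1(F)CCC(c2nc3cnc(Nc4ccc(C(F)(F)F)cn4)cc3[nH]2)CC1` differs from compound 3 in one place: 4,4-difluorocyclohexyl in place of 3,4-difluorophenyl on an aromatic carbon. For the measured compounds named here, no measured step concerns this change. Going by the values given here, the one measured step, a number 81.5 percentage points higher from compound 2 to compound 3 (beyond the scatter), concerns the trifluoromethyl, which compound 4 keeps. With no guidance on the ring exchange itself, compound 4 is expected to stay near compound 3, with a step of a number 11 percentage points lower from compound 3 to compound 4 (beyond the scatter) that may fall within the scatter. The estimate for compound 4 is 78%, ranging from 50% to 96%.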

Compound 4, percent of the compound remaining: 73%
For compound 4 the middle estimate is 5 percentage points above the measured one, within the range that was stated.
By their numbers in this assay, from the lowest: compound 2; then compound 1; then compound 4; then compound 3.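

Exchanging 3,4-difluorophenyl for 4,4-difluorocyclohexyl at this position gives a number 16 percentage points lower from compound 3 to compound 4 (beyond the scatter) in this assay, so a high number here does not require an aromatic ring of carbon only, although the exchange carries a modest cost. The two groups match in heavy atoms, yet the change alters both ring type and fluorine placement, and the pair cannot separate these. No measurement shown explains the step.

The compounds shown leave open how plain cyclohexyl, without fluorine, or a piperidine ring, which holds an amine, would read at this position. They also leave open whether the step would persist without the trifluoromethyl.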